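Methyl Added to a Tetracyclic Compound with a High Inhibition Number

The source may hold more compounds than are shown below. What is called first, only, known or untested is meant among the compounds shown, and "the series" means these compounds.

Four compounds share one fused core and are compared in an assay on isolated protein for inhibition of DNA topoisomerase 1 (Homo sapiens), tested at 100 uM; a higher number here means more inhibition at the concentration tested (going by the name of the read-out), a lower number less inhibition. Compound 1, `Cn1c2c(c3ccccc3c1=O)CCOc1ccccc1-2`, carries a methyl on its ring nitrogen; in this assay compound 1 is reported as "not active" (no number reported). Compound 2, `Cc1ccc2c(=O)n(C)c3c(c2c1)CCOc1ccccc1-3`, keeps that nitrogen methyl and adds a methyl on an aromatic ring; compound 2 is likewise reported as "not active" (no number reported). Compound 3, `COc1ccc(Cn2c3c(c4ccccc4c2=O)CCOc2ccccc2-3)cc1`, instead bears a methoxybenzyl group on the nitrogen, and in this assay compound 3 gives 94.5%. Among the compounds with values here, compound 3 thus stands alone among the three as the only one with a number at all, and that number is high; the two others come back without one.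

Compound 4, `COc1ccc(Cn2c3c(c4cc(C)ccc4c2=O)CCOc2ccccc2-3)cc1`, is compound 3 with one change: methyl in place of hydrogen on an aromatic carbon. The same kind of methyl appears when compound 1 is set beside compound 2, and both of those are reported as not active, so nothing there shows what the methyl does on its own. A small change of this kind is expected to leave the high inhibition of compound 3 largely in place, so the step of a number 6.5 percentage points lower from compound 3 to compound 4 (within the scatter) is expected to stay within the usual scatter. Compound 4 is therefore estimated at 88%, with a range from 55% to 99%.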

Compound 4, a percentage reported as inhibition, at one concentration (the size of the read-out at that concentration, not a potency): "not active" (no number reported)
The entry for compound 4 holds no number, so the estimate cannot be set against anything.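

Within the data shown here, compound 3 has a number and compound 4 has none, so no step between the two can be read. The compounds shown leave open how far the methyl on the aromatic ring alters inhibition when a methoxybenzyl group sits on the nitrogen. No measurement shown here offers an explanation for the entry of compound 4.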